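The compounds below may be only part of what the source reports. "The series", "measured", "known", "first", "only" and "open" are said of these compounds alone.

Series notes, thiophene-type core as drawn in the structures below.

Compound 1 `CC(C)(C)Cc1c(-c2cccnc2)sc(N)c1C(=O)c1ccc(Cl)cc1` is measured in an assay on CHO cells for displacement of a labelled ligand from adenosine receptor A3 (Homo sapiens), read by scintillation counting, tested at 10 uM (on this read-out higher numbers stand for more inhibition at the one concentration tested (going by the name of the read-out) and lower numbers for less inhibition), where compound 1 gives 1%. Compound 2 `CC(C)(C)Cc1csc(N)c1C(=O)c1cccc(C(F)(F)F)c1` gives 1% in this assay, and compound 3 `CC(C)(C)Cc1c(Br)sc(N)c1C(=O)c1cccc(C(F)(F)F)c1` gives 4%. Compound 1 stands level with compound 2 at the digits reported, and the two together are the lowest of the three numbers; the gap from compound 1 to compound 3 is within the scatter, so no order among the three can be read from these figures.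

Among the compounds with values here, the only single-point step measured so far is a number 3 percentage points higher from compound 2 to compound 3 (within the scatter), which lies within the scatter.

The next compound, compound 4 `COc1ccc(-c2sc(N)c(C(=O)c3ccc(Cl)cc3)c2CC(C)(C)C)cc1`, differs from compound 1 as follows: 4-methoxyphenyl in place of pyridin-3-yl on an aromatic carbon. Within the data shown here, no measured step touches a change of this kind; the bromo-for-hydrogen step from compound 2 to compound 3 concerns a different position and a different group and does not bear on it. Among the measured compounds shown here, since every number so far sits at the low end of the read-out, the working expectation is that compound 4 stays there as well, with a step of a number 2 percentage points higher from compound 1 to compound 4 (within the scatter) that is expected to remain within the scatter. Compound 4 is estimated at 3%, with a range from 0% to 15%.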

Compound 4, a percentage reported as inhibition, at one concentration (the size of the read-out at that concentration, not a potency): 2%
The estimate for compound 4 lay 1 percentage points above the measured number; the measured number falls inside the stated range.
By their numbers in this assay, from the lowest: compounds 1, 2, 4 and 3 (each within the scatter of the next).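

With 4-methoxyphenyl in place of pyridin-3-yl on the aromatic carbon next to the ring sulfur, this assay gives a number 1 percentage points higher from compound 1 to compound 4 (within the scatter), the first step measured between two six-membered aromatic rings at this position. At this position, therefore, a ring with 1 hetero atom and a carbon-only ring bearing a methoxy group are not separated by this read-out, even though the entering group is larger by the heavy-atom counts of 6 and 8, and both compounds stay at the low end of the percentages seen so far. No independent data on the compounds offer an explanation for this result.

The shown compounds leave open whether a carboxylic acid or a basic amine such as piperidine, carried on this aromatic ring or placed directly at this position, would move the read-out beyond the scatter. Also open, as far as these compounds go, is how hydrogen or bromo at this position compares with these two rings while the group of 9 heavy atoms on the core of compound 1 stays in place, since compound 2 and compound 3 differ from compound 1 in that group as well.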